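From compound 3 to compound 4: losing the phenyl

The source may hold more compounds than are shown below. What is called first, only, known or untested is meant among the compounds shown, and "the series" means these compounds.

Among the measured compounds shown here, in a functional assay on SMMC-7721 cells (Homo sapiens) for antiproliferative activity, read by MTT assay, with a stated time of 48 h (a higher number here means a weaker inhibitor, a lower number a stronger inhibitor), compound 3 `Cn1cc(C2=C(c3nn(CCCn4ccnc4)c4ncccc34)C(=O)N(c3ccccc3)C2=O)c2ccccc21` gives 34800 nM, the only actual number in this small set. Compound 4 `Cn1cc(C2=C(c3nn(CCCn4ccnc4)c4ncccc34)C(=O)NC2=O)c2ccccc21` differs from it by hydrogen in place of phenyl on an amide-type nitrogen in a ring. For the measured compounds named here, no measured step makes this change alone, so the evidence is indirect. Compound 1 `Cn1cc(C2=C(c3nn(CCCn4cncn4)c4ncccc34)C(=O)NC2=O)c2ccccc21` carries the amide hydrogen and gives > 100000 nM, which is a limit of the assay. Compound 2 `Cn1cc(C2=C(c3nn(CCCn4cccc4)c4ncccc34)C(=O)NC2=O)c2ccccc21` also carries it and gives > 100000 nM, likewise a limit. Together they account for (the limit of > 100000 nM in this assay, at which 2 of the 3 values shown sit). Going by the values given here, the one measured step, a step that the two limits leave unreadable from compound 1 to compound 2, offers no size to borrow. Given compound 1 at > 100000 nM, a limit, a rise in the number in this assay, meaning a weaker inhibitor, is expected for compound 4. The expected change is a 2.0-fold higher number from compound 3 to compound 4 (0.30 log units; within the scatter), a modest and uncertain estimate. A report of only a limit is about as likely as a number. For compound 4 the estimated value is 70000 nM, with an expected range from 20000 nM to 200000 nM.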

Compound 4, half-maximal inhibitory concentration: > 100000 nM
Compound 4 ended at the assay's limit; the forecaster's own chance of this, stated with the estimate: 50%; middle value at least 1.4-fold (0.15 log units) from the limit.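

In this assay, among the compounds shown here, hydrogen in place of phenyl on an amide-type nitrogen in a ring gives an at least 2.8-fold higher number from compound 3 to compound 4 (0.45 log units; beyond the scatter) and so provides the first readable step in this set. For the compounds shown here, compound 3, the only compound here that carries the phenyl, is also the only one with an actual number, while compound 1, compound 2 and compound 4, which all carry the amide hydrogen, stay at a limit whichever of 1H-1,2,4-triazol-1-yl, 1H-pyrrol-1-yl or 1H-1,2,4-imidazol-free chain end they bear. The steps among those three cannot be read, since each value is only a limit of the assay: the limit of > 100000 nM in this assay, at which 3 of the 4 values shown sit.

On these data alone, how large the full step from compound 3 to compound 4 is stays open. As far as these compounds go, it also remains open whether a methyl or benzyl group on that nitrogen would give a number, and whether the phenyl would do so alongside 1H-pyrrol-1-yl.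

Correction to the second sentence: the chain ends are 1H-1,2,4-triazol-1-yl, 1H-pyrrol-1-yl and 1H-imidazol-1-yl.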